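One Exchange at the Carbonyl of Compound 2

This account rests on a few compounds, and the source may have more. Where it says the series, first, only, none or still open, it means among the compounds named here.

Of the compounds shown here, two have so far been measured in an assay on cells with melanin-concentrating hormone receptor 1 (Homo sapiens) as the target, read by radioligand binding; on this read-out lower numbers stand for stronger inhibition and higher numbers for weaker inhibition. Compound 1 `CC(CNCC1CC1)Oc1cccc2ccc(N)nc12` gives 80 nM in this assay. Compound 2 `COc1cccc(C(=O)NCCCOc2cccc3ccc(N)nc23)c1` gives 2 nM, the lowest of the two numbers, and its gap to compound 1 lies beyond the scatter. Compound 3 `Nc1ccc2cccc(OCCCNC(=O)Nc3cccc(Cl)c3)c2n1` has not yet been measured. It differs from compound 2 in one place: (3-chlorophenyl)amino in place of 3-methoxyphenyl on a carbonyl carbon. Among the compounds with values here, no step between measured compounds matches this change, so the expectation rests on compound 2 alone. Because compound 2 gives 2 nM, the starting point is already strong, and swapping one aromatic arm for another with the same count of heavy atoms is expected to move the number only modestly, in either direction, at about the size of the scatter. Compound 3 is therefore expected to give 4 nM, with a range from 1 nM to 20 nM. The expected step from compound 2 to compound 3 is a 2.0-fold higher number from compound 2 to compound 3 (0.30 log units; within the scatter), a small shift toward weaker inhibition.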

Compound 3, half-maximal inhibitory concentration: 0.9 nM
Compound 3: the middle estimate sits 4.4-fold (0.65 log units) above what was measured; the measured number lies below the stated range.
By their numbers in this assay, from the lowest: compound 3; then compound 2; then compound 1.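

At this carbonyl carbon, the exchange of 3-methoxyphenyl for (3-chlorophenyl)amino in this assay gives a 2.2-fold lower number from compound 2 to compound 3 (0.35 log units; beyond the scatter), so a starting point that was already strong still improved. The entering group has a hydrogen-bond donor that the leaving group lacks, at the same count of heavy atoms, which shows that this position accepts an amide-type nitrogen on the carbonyl carbon together with a chlorine on the aromatic ring without any loss. Nothing measured here accounts for the gain, which stands as an observation only.

The exchange alters two things at once, and the compounds shown do not separate them: 3-chlorophenyl or (3-methoxyphenyl)amino on the same carbonyl carbon would do so. From the compounds shown here alone, how a fluorine or a nitrile in place of the chlorine would fare also remains open.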